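Ester variants of a shared core: stability notes

A few compounds are considered here, and "the series" means these few. Any claim that something is new, unique, unknown or untested is made for them only; others in the source may bear on it.

Measured so far:
- compound 1, `CCC(CC)C(=O)OCOC(=O)C1=C(S[C@@H]2CN[C@H](C(=O)Nc3cccc(C(=O)O)c3)C2)[C@H](C)[C@@H]2[C@@H]([C@@H](C)O)C(=O)N12`: > 95% in an ADME assay for metabolic stability, read by LC-MS, with a stated time of 3 h, at pH 6.5, tested at 50 uM; on this read-out lower numbers stand for a less stable compound and higher numbers for a more stable compound
- compound 2, `C[C@@H](O)[C@H]1C(=O)N2C3=C(S[C@@H]4CN[C@@H](C4)C(=O)Nc4cccc(c4)C(=O)OCCCOC3=O)[C@H](C)[C@H]12`: > 95% in this assay

For compound 1 the value in this assay is a limit of the measurement, not a number. For compound 2 the value is likewise a limit. Among the compounds with values here, both sit at the limit of > 95% in this assay, at which 2 of the 2 values shown sit, so no step between them can be read; compound 1 stands at the upper end of what the assay reports.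

Compound 3, `C[C@@H](O)[C@H]1C(=O)N2C(C(=O)OCC(F)(F)F)=C(S[C@@H]3CN[C@H](C(=O)Nc4cccc(C(=O)O)c4)C3)[C@H](C)[C@H]12`, is not yet measured. It differs from compound 1 by trifluoromethyl in place of ((pentan-3-yl)carbonyl)oxy on a saturated chain carbon bound to an oxygen next to a carbonyl group. Within the data shown here, no measured step of this kind exists. From the limit values shown, compound 1 gives no sign of loss here, and the shared core is the same; the expected step of a number at least 3 percentage points lower from compound 1 to compound 3 (that floor lies within the scatter) is therefore no more than the scatter, though a small drop is possible. Compound 3 is expected at 92%, within 75% to 99%.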

Compound 3, percent of the compound remaining: > 95%
Compound 3: only a limit was reported; the forecaster's own chance of this, stated with the estimate: 55%; middle value at least 3 percentage points from the limit.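

In this assay compound 3 gives > 95%, which is a limit. No step between compound 1 and compound 3 can be read: the limit of > 95% in this assay, at which 3 of the 3 values shown sit.

Going by these compounds, whether compound 1, compound 2 and compound 3 differ in stability at all remains open.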